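The source may report more compounds than this note shows. Statements on the series, on what has been measured and on what is new or still open speak of the compounds shown alone.

In a functional assay on OVCAR cells (Homo sapiens) for inhibition, read by MTT assay, with a stated time of 48 h (a lower number here means a stronger inhibitor of growth, a higher number a weaker inhibitor of growth), compound 2 `O=[N+]([O-])c1ccc(-c2cc(-c3ccc(Br)cc3)n[nH]2)cc1` gives 17500 nM, the lower of the two numbers measured, and the nearest is compound 1 `COc1ccc(-c2cc(-c3ccc([N+](=O)[O-])cc3)[nH]n2)cc1`, which gives 27300 nM. Within the data shown here, the only measured step, a 1.6-fold lower number from compound 1 to compound 2 (0.19 log units; within the scatter), lies within the scatter. Compound 3 `COc1ccc(-c2cc(-c3ccc(Br)cc3)n[nH]2)cc1` differs from compound 2 by methoxy in place of nitro on an aromatic carbon. No measured step touches that ring, so nothing shown predicts a shift beyond the scatter, and the step is expected to be a 1.1-fold higher number from compound 2 to compound 3 (0.06 log units; within the scatter). For compound 3 the estimate is 20000 nM, within a range from 7000 nM to 55000 nM.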

Compound 3, concentration for 50% growth inhibition: 20700 nM
For compound 3 the middle estimate is 1.0-fold (0.01 log units) below the measured one, and the stated range covers the measured number.
By their numbers in this assay, from the lowest: compounds 2, 3 and 1 (each within the scatter of the next).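

Replacing nitro with methoxy para to a large group, with the bromo-bearing ring held constant, gives a 1.2-fold higher number from compound 2 to compound 3 (0.07 log units; within the scatter) in this assay. This is the first change shown at this position, and it joins the earlier change on the other ring as a step that stays within the scatter. No evidence is available that would explain this result. Going by these compounds, whether an amine or a carboxylic acid at this position would give a step beyond the scatter remains open, as does the effect of a longer alkoxy chain in place of methoxy.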